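Three Compounds at a Limit, a Fourth Awaiting Measurement

This account rests on a few compounds, and the source may have more. Where it says the series, first, only, none or still open, it means among the compounds named here.

Compound 1, `CC/C=C/[C@H](CC)C[C@@]1(C)C[C@@H](CC)[C@@H](CC(=O)OC)OO1`, gives > 10000 nM in a functional assay on Microglia cells (Rattus norvegicus), read by LDH release; on this read-out higher numbers stand for weaker inhibition and lower numbers for stronger inhibition.
Compound 2, `CC/C=C/[C@H](CC)C/C(=C/[C@@]1(CC)C[C@H](CC)[C@H](CC(=O)O)OO1)CC`, gives > 10000 nM in this assay.
Compound 3, `CC/C=C/[C@H](CC)C[C@]1(CC)C=C(CC)/C(=C/C(=O)OC)O1`, gives > 10000 nM in this assay.

Each of these three values is a limit of this assay and not a number. Compound 3 therefore stands at the limit of > 10000 nM in this assay, at which 3 of the 3 values shown sit, and nothing in the numbers separates it from compound 1 or compound 2. Among the compounds with values here, no step between two measured compounds can be drawn from these values, so the size of any change must be judged from the structures alone.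

Compound 4, `CC/C=C/[C@H](CC)C[C@]1(C)C=C(CC)/C(=C/C(=O)OC)O1`, has not yet been measured in this assay. It differs from compound 3 by hydrogen in place of methyl on a saturated chain carbon bound to a saturated ring carbon. This removes a single carbon from a chain on the shared core of compound 3 and leaves everything else in place.

Compound 3 gives > 10000 nM in this assay, which is a limit. On that footing the step that the limit leaves unreadable from compound 3 to compound 4 is expected to be none beyond the scatter, and a further limit rather than a number is the likelier outcome. Compound 4 is accordingly expected to give about 20000 nM in this assay, within a range from 8000 nM to 60000 nM.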

Compound 4, half-maximal inhibitory concentration: > 10000 nM
Compound 4 gave a limit, no number (the forecaster's own chance of this, stated with the estimate: 85%); the middle value lies beyond the limit too.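

Compound 4 gives > 10000 nM in this assay, and this value is a limit. No step can be read between compound 3 and compound 4, and all the values shown sit at one point: the limit of > 10000 nM in this assay, at which 4 of the 4 values shown sit.

The compounds shown leave open how far beyond this limit each one lies, and whether the change from ethyl to methyl alters inhibition at all.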